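From hydroxyamino to aminoamino: notes on compound 4

The source may hold more compounds than are shown below. What is called first, only, known or untested is meant among the compounds shown, and "the series" means these compounds.

Measured so far in a toxicity assay on HepG2 cells (Homo sapiens) for inhibition, read by resazurin assay, with a stated time of 24 h; a higher number here means that more compound is tolerated, a lower number that less compound is tolerated (all three values are limits)
- compound 1 `CNC(=O)c1nc([N+](=O)[O-])cn1Cc1ccc(OC(F)(F)F)cc1` gives > 100000 nM (a limit)
- compound 2 `CN(C)C(=O)c1nc([N+](=O)[O-])cn1Cc1ccc(OC(F)(F)F)cc1` gives > 100000 nM (a limit)
- compound 3 `O=C(NO)c1nc([N+](=O)[O-])cn1Cc1ccc(OC(F)(F)F)cc1` gives > 100000 nM (a limit)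

Compound 3 stands at the same limit as the other two compounds (the limit of > 100000 nM in this assay, at which 3 of the 3 values shown sit) and so has no numerical place in the series. Compound 4 `NNC(=O)c1nc([N+](=O)[O-])cn1Cc1ccc(OC(F)(F)F)cc1` differs from compound 3 by amino in place of hydroxy on an amide-type nitrogen and carries amino in place of hydroxy on an amide-type nitrogen. The measured steps a step that the two limits leave unreadable from compound 1 to compound 2 and a step that the two limits leave unreadable from compound 1 to compound 3 and a step that the two limits leave unreadable from compound 2 to compound 3 bear on this change, and none of them gives a size. With compound 3 at > 100000 nM (a limit), no step beyond the scatter is expected in this assay and no direction can be assigned. The expected step is a number no higher from compound 3 to compound 4 (the limit leaves the size open) in size. For compound 4 the estimate is 100000 nM (expected range 40000 nM to 200000 nM).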

Compound 4, half-maximal cytotoxic concentration: > 100000 nM
Compound 4 was reported as a limit; the forecaster's own chance of this, stated with the estimate: 75%; the middle value sits exactly at the limit.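

In this assay no new step can be read between compound 4 and compound 1, compound 2 or compound 3, as all of them sit at one limit: the limit of > 100000 nM in this assay, at which 4 of the 4 values shown sit.

The compounds shown leave open where each half-maximal cytotoxic concentration actually lies, and so whether amino in place of hydroxy changes it at all.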